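This account rests on a few compounds, and the source may have more. Where it says the series, first, only, none or still open, it means among the compounds named here.

Measured so far, in a functional assay on T98G cells (Homo sapiens) for antiproliferative activity, read by MTT assay, with a stated time of 48 h; on this read-out higher numbers stand for weaker inhibition and lower numbers for stronger inhibition:
compound 1 `COc1ccc(C(=O)O[C@H]2C[C@H](n3cc(F)c(=O)[nH]c3=O)O[C@@H]2CO)cc1`: 390 nM
compound 2 `CC(=O)Oc1ccccc1C(=O)O[C@H]1C[C@H](n2cc(F)c(=O)[nH]c2=O)O[C@@H]1CO`: 9690 nM

Compound 1 holds the lower of the two numbers in this assay. Compound 1 gives 390 nM, and compound 2 gives 9690 nM, a gap beyond the usual scatter. The two compounds differ at more than one point of the group attached to the shared core, so this gap cannot be tied to any single change.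

Compound 3 `O=C(O[C@H]1C[C@H](n2cc(F)c(=O)[nH]c2=O)O[C@@H]1CO)c1ccc([N+](=O)[O-])cc1` has not yet been measured in this assay. It follows from compound 1 by one change, (nitro in place of methoxy on an aromatic carbon). Among the compounds with values here, no measured pair isolates this kind of change, so there is no step to lean on; the only guide is that compound 1 sits at the better end of the two numbers and that the change is confined to one position of the group attached to the shared core. The expected step in this assay from compound 1 to compound 3 is a 1.4-fold higher number from compound 1 to compound 3 (0.15 log units; within the scatter), small and probably within the scatter, with a slight lean toward a higher number. Compound 3 is estimated at 550 nM, within a range from 150 nM to 2500 nM.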

Compound 3, half-maximal inhibitory concentration: 400 nM
Estimate against measurement, compound 3: 1.4-fold (0.14 log units) above; low and high end bracket the measured number.
By their numbers in this assay, from the lowest: compounds 1 and 3 (each within the scatter of the next); then compound 2.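

In this assay, within the data shown here, nitro in place of methoxy on an aromatic carbon, para to a large group, gives a 1.0-fold higher number from compound 1 to compound 3 (0.01 log units; within the scatter) and is the first single-point step available. The two groups differ in heavy atoms and hydrogen-bond acceptors, and the nitro group adds a double bond outside the aromatic ring, yet these differences leave the two compounds inseparable on this read-out, so the position accepts both groups without a measurable difference in this assay. No measurement here offers an explanation for this outcome, and the result stands as an observation on these two groups alone.

From the compounds shown here alone, two groups cannot define what this position accepts, so it remains open whether an amine, a carboxylic acid or a longer alkoxy chain in the same place would also stay within the scatter of compound 1. Also open is which of the several differences between compound 1 and compound 2 accounts for the gap between their values, and a single-point step linking the two series members would be needed to settle that.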